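The source may hold more compounds than are shown below. What is called first, only, known or untested is meant among the compounds shown, and "the series" means these compounds.

Measured so far in a functional assay on KETR3 cells (Homo sapiens) for inhibition, read by MTT assay, with a stated time of 120 h; a lower number here means a stronger inhibitor, a higher number a weaker inhibitor:
compound 1 `CNC(=O)C#Cc1ccc(NC(=O)Nc2ccc(Cl)c(C(F)(F)F)c2)cc1`, compound 1 gives 24700 nM.
compound 2 `CC(NC(=O)c1cccc(-c2ccc(NC(=O)Nc3ccc(Cl)c(C(F)(F)F)c3)cc2)c1)c1ccccc1`, compound 2 gives 6460 nM.
compound 3 `CNC(=O)/C(C)=C/c1ccc(NC(=O)Nc2ccc(Cl)c(C(F)(F)F)c2)cc1`, compound 3 gives only > 50000 nM, which is an assay limit and not a number.

Compound 3 thus stands at the limit of > 50000 nM in this assay, at which 1 of the 3 values shown sits. For the measured compounds named here, only one measured step is recorded, an at least 2.0-fold higher number from compound 1 to compound 3 (0.30 log units; that floor lies within the scatter), and it concerns the linker, not the amide. Compound 4 `C/C(=C\c1ccc(NC(=O)Nc2ccc(Cl)c(C(F)(F)F)c2)cc1)C(=O)N1CC(C)OC(C)C1` differs from compound 3 by 2,6-dimethylmorpholin-4-yl in place of methylamino on a carbonyl carbon. Going by the values given here, no measured step bears on that change; compound 2 merely shows that a larger amide on the shared core can still return a measurable number. Compound 4 is therefore expected to remain weak, with an at least 1.2-fold lower number from compound 3 to compound 4 (0.09 log units; that floor lies within the scatter) estimated as no step beyond the scatter and a fair chance of another limit. The estimate for compound 4 is 40000 nM, range 10000 nM to 150000 nM.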

Compound 4, half-maximal inhibitory concentration: > 50000 nM
Compound 4: only a limit was reported (the forecaster's own chance of this, stated with the estimate: 50%); at least 1.2-fold (0.09 log units) between middle value and limit.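

No step can be read from compound 3 to compound 4, since both stand at a limit and neither gives a number: the limit of > 50000 nM in this assay, at which 2 of the 4 values shown sit.

From the compounds shown here alone, whether 2,6-dimethylmorpholin-4-yl in place of methylamino on a carbonyl carbon changes the read-out at all remains open.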